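Swapping an Aryl Ring for a Benzyloxy Chain

This account rests on a few compounds, and the source may have more. Where it says the series, first, only, none or still open, it means among the compounds named here.

Compound 1 `Cc1nn(-c2ncnc3nc[nH]c23)c2c1C(OCC(=O)c1ccc(F)cc1)CC(=O)N2`: in a functional assay on HEK293 cells for agonist activity at G-protein coupled receptor 39 (Homo sapiens), read by scintillation proximity assay and inositol phosphate accumulation, with a stated time of 75 min, in the presence of a further agent that is not named here (on this read-out higher numbers stand for an effect only at larger amounts of compound and lower numbers for an effect already at smaller amounts), compound 1 gives 3 nM.
Compound 2 `Cc1nn(-c2ncnc3nc[nH]c23)c2c1C(c1ccc(OC(C)C)cc1)CC(=O)N2`: in this assay compound 2 gives 18 nM.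
Compound 3 `CCC(C(=O)NC1CC(=O)Nc2c1c(C)nn2-c1ncnc2nc[nH]c12)c1ccccc1`: in this assay compound 3 gives 5 nM.

Among these three, compound 2 stands at the highest number. Compound 3 is its nearest neighbour and compound 1 its furthest, and both gaps are wider than the usual scatter of repeated measurements, so compound 2 is the one that needs the most material to show an effect.

Compound 4 `Cc1nn(-c2ncnc3nc[nH]c23)c2c1C(OCc1ccccc1Cl)CC(=O)N2` has not yet been measured. It differs from compound 2 at a single position: (2-chlorobenzyl)oxy in place of 4-isopropoxyphenyl on a saturated ring carbon. Among the measured compounds shown here, no pair of measured compounds differs in exactly this way, so the size of the step can only be anticipated. A fall to a clearly lower number seems likely, because compound 1 gives 3 nM while carrying a chain that also starts with an oxygen at this saturated ring carbon. The step of a 3.6-fold lower number from compound 2 to compound 4 (0.56 log units; beyond the scatter) is therefore expected to lie beyond the scatter, toward smaller amounts. Compound 4 is estimated to give about 5 nM, with a likely range from 1.5 nM to 18 nM.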

Compound 4, half-maximal effective concentration: 2 nM
For compound 4 the middle estimate is 2.5-fold (0.40 log units) above the measured one; the measured number falls inside the stated range.
By their numbers in this assay, from the lowest: compounds 4, 1 and 3 (each within the scatter of the next, the first and the last beyond it); then compound 2.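

In this assay, putting (2-chlorobenzyl)oxy in place of 4-isopropoxyphenyl on the saturated ring carbon gives a 9.0-fold lower number from compound 2 to compound 4 (0.95 log units; beyond the scatter), a step beyond the scatter and the first that can be read directly at this position. It shows that the number responds to which group this carbon carries. With an oxygen kept on that carbon, 2-chlorophenyl in place of (4-fluorophenyl)carbonyl on the chain gives a 1.5-fold lower number from compound 1 to compound 4 (0.18 log units; within the scatter), a step within the scatter, so compound 1 and compound 4 cannot be told apart here, and nothing measured on these compounds gives a reason for either step.

Going by these compounds, the step from compound 2 exchanges the whole group at once, so it remains open how much of it belongs to the oxygen on the ring carbon, how much to the chain carbon that follows, and how much to the chlorine. A plain benzyloxy group without chlorine could begin to separate these parts, while an amine or a carboxylic acid on the benzyl ring would test how far the result holds for very different groups.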